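The source may report more compounds than this note shows. Statements on the series, on what has been measured and on what is new or still open speak of the compounds shown alone.

Measured so far:
compound 1 `Cc1c(O)ccc2c1[C@H](Cn1cc(-c3ccc(Cl)cc3)nn1)[C@@]13CC(=O)[C@@](C)(CC[C@@H]21)C3`: > 20000 nM in a functional assay on SMMC-7721 cells (Homo sapiens) for cytotoxicity, read by MTT assay, with a stated time of 4 days (on this read-out lower numbers stand for stronger inhibition and higher numbers for weaker inhibition), a limit of the assay
compound 2 `Cc1ccc(S(=O)(=O)Oc2ccc3c(c2C)[C@H](Cn2cc(-c4ccc(Cl)cc4)nn2)[C@@]24CC(=O)[C@@](C)(CC[C@@H]32)C4)cc1`: > 20000 nM in this assay, a limit of the assay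
compound 3 `Cc1ccc(S(=O)(=O)Oc2ccc3c(c2C)[C@H](Cn2cc(-c4ccccn4)nn2)[C@@]24CC(=O)[C@@](C)(CC[C@@H]32)C4)cc1`: > 20000 nM in this assay, a limit of the assay

Compound 1 arises from compound 2 by hydrogen in place of (4-methylphenyl)sulfonyl on an oxygen on an aromatic ring; in this assay this gives a step that the two limits leave unreadable from compound 2 to compound 1. Compound 3 arises from compound 2 by pyridin-2-yl in place of 4-chlorophenyl on an aromatic carbon, and this is also how the core of compound 3 differs from that of compound 2; the step is a step that the two limits leave unreadable from compound 2 to compound 3. Compound 4 `Cc1c(O)ccc2c1[C@H](Cn1cc(-c3ccccn3)nn1)[C@@]13CC(=O)[C@@](C)(CC[C@@H]21)C3` is not yet measured. It differs from compound 3 by hydrogen in place of (4-methylphenyl)sulfonyl on an oxygen on an aromatic ring, the same change that leads from compound 2 to compound 1, at the same place.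

Because (the limit of > 20000 nM in this assay, at which 3 of the 3 values shown sit), no finite reference value exists in this series, and the measured step of that change is not readable. For compound 4 the expectation in this assay is therefore that it also reports only a limit; compound 4 is estimated at 40000 nM, between 15000 nM and 200000 nM, corresponding to an expected step that the limit leaves unreadable from compound 3 to compound 4.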

Compound 4, half-maximal inhibitory concentration: > 20000 nM
Compound 4 gave a limit, no number; the forecaster's own chance of this, stated with the estimate: 85%; the middle value is on the limit's open side.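

In this assay no step can be read from compound 3 to compound 4 or from compound 1 to compound 4, since every value is a limit of the assay: the limit of > 20000 nM in this assay, at which 4 of the 4 values shown sit.
The compounds shown leave open whether either change, hydroxy for ((4-methylphenyl)sulfonyl)oxy or pyridin-2-yl for 4-chlorophenyl, alters cytotoxicity at all.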